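A Benzyloxy Variant of Two Non-Toxic Compounds

The source may report more compounds than this note shows. Statements on the series, on what has been measured and on what is new or still open speak of the compounds shown alone.

Compound 1 `O=C1c2ccccc2N(Cc2ccccc2Cl)S(=O)(=O)N1Cc1ccccc1Cl` was tested in a functional assay on HEL cells (Homo sapiens) for inhibition; on this read-out lower numbers stand for higher toxicity in this test and higher numbers for lower toxicity in this test. In this assay compound 1 gives > 200000 nM, which is a limit of the test rather than a measured number. Compound 2 `O=C1c2ccccc2N(Cc2cccc(Cl)c2)S(=O)(=O)N1Cc1ccccc1` likewise gives > 200000 nM, again only a limit. The picture so far is the limit of > 200000 nM in this assay, at which 2 of the 2 values shown sit, so nothing can be said about order between them. Compound 3 `O=C1c2ccccc2N(Cc2ccccc2Cl)S(=O)(=O)N1COCc1ccccc1` differs from compound 1 by benzyloxy in place of 2-chlorophenyl on a saturated chain carbon bound to an amide-type nitrogen in a ring. Among the compounds with values here, with no measured step available, the expected step is a number no higher from compound 1 to compound 3 (the limit leaves the size open), which means no change beyond the scatter. Compound 3 is therefore estimated at 200000 nM, with a range from 50000 nM to 200000 nM, most likely reported once more as a limit.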

Compound 3, half-maximal cytotoxic concentration: > 50000 nM
Compound 3 ended at the assay's limit; the forecaster's own chance of this, stated with the estimate: 85%; the middle value does not contradict the limit.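

Within the data shown here, compound 1 and compound 3 both end at limits rather than measured numbers, so no step between them can be read. On these data alone, whether benzyloxy in place of 2-chlorophenyl changes toxicity at all stays open.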